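The compounds below may be only part of what the source reports. "The series", "measured", "known", "first", "only" and "open" are said of these compounds alone.

In a functional assay on MT4 cells (Homo sapiens) (a higher number here means that more compound is tolerated, a lower number that less compound is tolerated), compound 2 (`COC(=O)CNC1=CS(=O)(=O)O[C@@]12[C@@H](CO[Si](C)(C)C(C)(C)C)O[C@@H](n1cc(C)c(=O)n(C)c1=O)[C@@H]2O[Si](C)(C)C(C)(C)C`) gives 105000 nM as its reading. Compound 3 (`Cc1cn([C@@H]2O[C@@H]3COC4(O)CS(=O)(=O)O[C@@]34[C@H]2O)c(=O)[nH]c1=O`) gives 100000 nM in the same test, and these two values lie within the scatter of each other. Compound 1 (`Cc1cn([C@@H]2O[C@@H]3COC(=O)[C@]3(OS(C)(=O)=O)[C@H]2O)c(=O)[nH]c1=O`) is reported as >= 250000 nM in this test, and that figure is a limit of the assay and not a number.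

Compound 4 (`Cc1cn([C@@H]2O[C@H](CO[Si](C)(C)C(C)(C)C)[C@@]3(OS(=O)(=O)C=C3NCC(=O)OCc3ccccc3)[C@H]2O[Si](C)(C)C(C)(C)C)c(=O)n(C)c1=O`) differs from compound 2 in one place, by phenyl in place of hydrogen on a saturated chain carbon bound to an oxygen next to a carbonyl group on a saturated chain carbon bound to an oxygen next to a carbonyl group, which turns methoxycarbonyl to benzyloxycarbonyl. For the measured compounds named here, no measured pair shows what this change does in this assay so any forecast is uncertain. The expectation is a small move toward a lower number, meaning somewhat less compound tolerated, and it may be no larger than the scatter. The estimated step is a 1.8-fold lower number from compound 2 to compound 4 (0.24 log units; within the scatter) in that direction. For compound 4 the expected value is 60000 nM with an estimated range of 20000 nM to 180000 nM around it.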

Compound 4, half-maximal cytotoxic concentration: 250000 nM
The estimate for compound 4 lay 4.2-fold (0.62 log units) below the measured number, outside the stated range (above it).
By their numbers in this assay, from the lowest: compounds 3 and 2 (each within the scatter of the next); then compound 4.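

For the compounds shown here, until now no measured pair showed what any change at this place does. Phenyl in place of hydrogen on a saturated chain carbon bound to an oxygen next to a carbonyl group, which turns methoxycarbonyl to benzyloxycarbonyl, gives in this assay a 2.4-fold higher number from compound 2 to compound 4 (0.38 log units; beyond the scatter) and so a modest rise in how much compound is tolerated. The true size of this step may be hidden, since compound 4 reads the same figure that stands for compound 1 as a limit of the assay and not a number: the limit of >= 250000 nM in this assay, at which 1 of the 4 values shown sits.

Whether the rise needs the phenyl ring itself stays open, since only this one replacement is shown. Also open, as far as these compounds go, is what an ethoxycarbonyl group or a free carboxylic acid at this place would do to the tolerated amount.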